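Hydrogen for Methoxy on a Glycosylated Diarylheptanoid

The compounds below may be only part of what the source reports. "The series", "measured", "known", "first", "only" and "open" are said of these compounds alone.

Measured so far:
Compound 1 `OC[C@H]1O[C@@H](O[C@H](CCc2ccc(O)cc2)C[C@H](O)CCc2ccc(O)c(O)c2)[C@H](O)[C@@H](O)[C@@H]1O` gives 5.5 ug/mL in a functional assay on HL-60 cells (Homo sapiens) for cytotoxicity, read by MTT assay, with a stated time of 72 h; on this read-out lower numbers stand for stronger inhibition and higher numbers for weaker inhibition.
Compound 2 `COc1cc(CC[C@H](C[C@H](O)CCc2ccc(O)cc2)O[C@@H]2O[C@H](CO)[C@@H](O)[C@H](O)[C@H]2O)ccc1O` gives only a limit in this assay, namely > 10 ug/mL.

Compound 2 therefore has no exact number; it stands at the edge of what this assay could record: the limit of > 10 ug/mL in this assay, at which 1 of the 2 values shown sits. Of the two measured compounds, only compound 1 yields a number within range, so the two values show compound 2 as the weaker of the pair on this read-out, without telling how much weaker.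

Compound 3 `OC[C@H]1O[C@@H](O[C@H](CCc2ccc(O)cc2)C[C@H](O)CCc2ccc(O)cc2)[C@H](O)[C@@H](O)[C@@H]1O` differs from compound 2 in one place: hydrogen in place of methoxy on an aromatic carbon. Among the measured compounds shown here, no measured pair here isolates this change, so the size of the step cannot be read off from existing data. Compound 3 shares its sugar and chain with both measured compounds and carries the plainer phenol of the two.

Because compound 2 sits at the limit > 10 ug/mL, the step expected from compound 2 to compound 3 is a step that the limit leaves unreadable from compound 2 to compound 3, and no change beyond the usual scatter is anticipated. Compound 3 is estimated at 12 ug/mL in this assay, expected between 5 ug/mL and 30 ug/mL.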

Compound 3, half-maximal inhibitory concentration: > 10 ug/mL
Compound 3 was reported as a limit; the forecaster's own chance of this, stated with the estimate: 55%; the middle value lies beyond the limit too.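

In this assay, compound 3 also returns only a limit, > 10 ug/mL. The swap of methoxy for hydrogen on this aromatic carbon therefore has no readable size, as neither end of the change is an exact number, and the values now gather at one edge of what the assay records: the limit of > 10 ug/mL in this assay, at which 2 of the 3 values shown sit.

What this result adds is a second comparison at the same position, where hydrogen replaces the hydroxy group of compound 1, and it gives an at least 1.8-fold higher number from compound 1 to compound 3 (0.25 log units; that floor lies within the scatter), so even this pair does not establish that the hydroxy group matters, although compound 1 remains the only one of the three with an exact number.

Still open, as far as these compounds go, is how far compound 2 and compound 3 lie past the limit, and whether they differ from each other at all. Also open, from the compounds shown here alone, is how this position would respond to other small groups, such as an amine, a chlorine atom or an ethoxy group, any of which would help only if it gave an exact number in this assay.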